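The source may hold more compounds than are shown below. What is called first, only, known or untested is meant among the compounds shown, and "the series" means these compounds.

For the measured compounds named here, in a functional assay on B16 cells (Mus musculus) for inhibition, with a stated time of 3 days (on this read-out lower numbers stand for stronger inhibition and higher numbers for weaker inhibition), compound 1 `Oc1cc(OCc2ccccc2Cl)cc(OCc2ccccc2Cl)c1` carries the entry "not determined" (no result reported), so compound 2 `Oc1ccc(OCc2cccc(Cl)c2)cc1`, at 1830 nM, provides the only number and has nothing to be ranked against. Compound 3 `Oc1ccc(OCc2ccc(Cl)c(Cl)c2)cc1` differs from compound 2 by one change, (chloro in place of hydrogen on an aromatic carbon), which places chloro in place of hydrogen on an aromatic carbon. Going by the values given here, no measured step shows what such a change does here, so any forecast stays cautious. The expected change is a 1.5-fold lower number from compound 2 to compound 3 (0.18 log units; within the scatter), a small move toward stronger inhibition that may not exceed the usual scatter. Compound 3 is estimated at 1200 nM, with an expected range of 350 nM to 4000 nM.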

Compound 3, half-maximal inhibitory concentration: 1870 nM
Beside the measured number, compound 3's estimate is 1.6-fold (0.19 log units) below it; low and high end bracket the measured number.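

In this assay, for the compounds shown here, placing a chloro group on the aromatic carbon ortho to the existing chloro group gives a 1.0-fold higher number from compound 2 to compound 3 (0.01 log units; within the scatter) and is the first measured step in this set. This position therefore accepts a second chloro group with no real shift in inhibition, so this single change neither gains nor loses anything measurable here. Nothing available explains this flat result. From the compounds shown here alone, whether a methoxy group, an amine or a carboxylic acid on this same carbon would also leave the number unmoved stays open.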